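The source may hold more compounds than are shown below. What is called first, only, known or untested is meant among the compounds shown, and "the series" means these compounds.

In a functional assay (trachea) with Cavia porcellus as the target (on this read-out higher numbers stand for weaker inhibition and lower numbers for stronger inhibition), compound 1 `CCn1nc(-c2cccnc2)c2ccccc2c1=O` gives 1320 nM, while compound 2 `CC(C)n1nc(-c2cccnc2)c2ccccc2c1=O` gives 3090 nM, the higher of the two numbers. Compound 3 `CC(C)=CCn1nc(-c2cccnc2)c2ccccc2c1=O` carries 3-methylbut-2-en-1-yl in place of isopropyl on an aromatic nitrogen. Within the data shown here, only one measured step bears on this change: a 2.3-fold higher number from compound 1 to compound 2 (0.37 log units; beyond the scatter), a modest rise on adding a methyl to the chain. Among the measured compounds shown here, no measured compound has a double bond in this chain, so the expectation is loose: a small further rise in this assay, no larger than that step. The expected change is a 1.3-fold higher number from compound 2 to compound 3 (0.11 log units; within the scatter). For compound 3 the estimated value is 4000 nM, with an expected range of 1200 nM to 13000 nM.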

Compound 3, half-maximal inhibitory concentration: 1380 nM
For compound 3 the middle estimate is 2.9-fold (0.46 log units) above the measured one; low and high end bracket the measured number.
By their numbers in this assay, from the lowest: compounds 1 and 3 (each within the scatter of the next); then compound 2.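

Moving from isopropyl to 3-methylbut-2-en-1-yl on the aromatic nitrogen gives a 2.2-fold lower number from compound 2 to compound 3 (0.35 log units; beyond the scatter) in this assay and so reverses the earlier rise. The comparison with the ethyl compound gives a 1.0-fold higher number from compound 1 to compound 3 (0.02 log units; within the scatter) and leaves those two compounds indistinguishable. Across these three compounds, then, a larger group on this nitrogen does not by itself mean a higher number.

From the compounds shown here alone, whether the double bond matters remains open, as does the effect of a saturated 3-methylbutyl chain or a benzyl group here. No evidence at hand explains this result.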